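Carbonyl substituent swap in a kinase inhibitor series

This account rests on a few compounds, and the source may have more. Where it says the series, first, only, none or still open, it means among the compounds named here.

For the measured compounds named here, compound 2 `CCCC(=O)Nc1cccc(NC(=O)COc2ccc3c(=O)ccoc3c2)c1` holds the only numerical reading in the set: in an assay on isolated protein for inhibition of Rho-associated protein kinase 1 (Homo sapiens), read by scintillation counting, radiometric assay and 33P incorporation, with a stated time of 40 min, in the presence of a further agent that is not named here (a higher number here means a weaker inhibitor, a lower number a stronger inhibitor), compound 2 gives 1430 nM. Compound 1 `CN(C)c1ccc(C(=O)Nc2cccc(NC(=O)COc3ccc4c(c3)CCC(=O)N4)c2)cc1` reaches only a limit of this assay, > 10000 nM, as recorded in the limit of > 10000 nM in this assay, at which 1 of the 2 values shown sits. Going by the values given here, no two measured compounds differ in one place, so no measured step is available to calibrate the change ahead.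

Compound 3 `O=C(COc1ccc2c(=O)ccoc2c1)Nc1cccc(NC(=O)c2cccc([N+](=O)[O-])c2)c1` is not yet measured in this assay. It differs from compound 2 by 3-nitrophenyl in place of propyl on a carbonyl carbon. Compound 1 carries a different group on that carbonyl and a different core, so its limit cannot be mapped onto compound 3 directly. The expected step is a 2.4-fold higher number from compound 2 to compound 3 (0.39 log units; beyond the scatter), in the direction of weaker inhibition and somewhat beyond the usual scatter, with a real chance that only a limit is returned. Compound 3 is estimated at 3500 nM, within a range from 900 nM to 15000 nM.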

Compound 3, half-maximal inhibitory concentration: 528 nM
Beside the measured number, compound 3's estimate is 6.6-fold (0.82 log units) above it; measured number below the stated range.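

Exchanging propyl for 3-nitrophenyl on the carbonyl carbon gives a 2.7-fold lower number from compound 2 to compound 3 (0.43 log units; beyond the scatter) in this assay. For the compounds shown here, this is the first measured step, and it shows that on the shared core this position accepts a six-membered aromatic ring in place of a short chain, with modestly stronger inhibition. The data at hand give no cause for this step.

From the compounds shown here alone, whether the change follows from the ring itself or from the nitro group stays open, and an unsubstituted phenyl, a 3-aminophenyl or a longer alkyl chain on this carbonyl would separate the two. Going by these compounds, compound 1 gives > 10000 nM, a limit of the assay, and it differs from compound 3 in more than one place, so the contribution of its core also stays open.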